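Bromovinyl for Methyl on an Acyclic Uracil Scaffold

The source may hold more compounds than are shown below. What is called first, only, known or untested is meant among the compounds shown, and "the series" means these compounds.

Compound 1 `Nc1cn(COC(CO)CO)c(=O)[nH]c1=O` and compound 2 `Cc1cn(COC(CO)CO)c(=O)[nH]c1=O` share one core and differ only in methyl in place of amino on an aromatic carbon. In a functional assay on Vero cells (Chlorocebus sabaeus) for cytotoxicity (on this read-out higher numbers stand for lower toxicity in this test and lower numbers for higher toxicity in this test), compound 1 reaches only the limit of the test, giving > 432000 nM. In this assay compound 2 likewise gives only a limit, > 434000 nM. The step that the two limits leave unreadable from compound 1 to compound 2 is therefore of unreadable size, as the limit of > 432000 nM in this assay, at which 1 of the 2 values shown sits, and the limit of > 434000 nM in this assay, at which 1 of the 2 values shown sits, show. Compound 3 `O=c1[nH]c(=O)n(COC(CO)CO)cc1/C=C/Br` carries 2-bromoethenyl in place of methyl on an aromatic carbon. Within the data shown here, no measured step bears directly on this change. With compound 2 at the limit, compound 3 is expected to stay low in toxicity, with an estimated step of an at least 1.0-fold lower number from compound 2 to compound 3 (0.03 log units; that floor lies within the scatter). Compound 3 is estimated at 400000 nM, between 100000 nM and 1000000 nM.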

Compound 3, half-maximal cytotoxic concentration: > 311000 nM
Compound 3: a limit, no number (the forecaster's own chance of this, stated with the estimate: 70%); the middle value is on the limit's open side.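

In this assay compound 3 gives only a limit, > 311000 nM. Its steps from compound 1 and from compound 2 therefore cannot be read. The compounds shown leave open at what concentration any of the three harms these cells.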